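Replacing dimethylamino in compound 2

A few compounds are considered here, and "the series" means these few. Any claim that something is new, unique, unknown or untested is made for them only; others in the source may bear on it.

Measured in a functional assay on B16-F0 cells (Mus musculus) for inhibition, read by CCK-8 assay, with a stated time of 48 h; on this read-out higher numbers stand for weaker inhibition and lower numbers for stronger inhibition:
- compound 1 `COc1cc(-c2ccnc3cc(-c4ccc(C(F)(F)F)cc4)nn23)cc(OC)c1OC`: 1770 nM
- compound 2 `COc1cc(-c2ccnc3cc(-c4ccc(N(C)C)cc4)nn23)cc(OC)c1OC`: 702 nM
- compound 3 `COc1cc(-c2ccnc3cc(-c4ccc5cnn(C)c5c4)nn23)cc(OC)c1OC`: 1000 nM

Compound 2 stands at the low end of these numbers, a place it shares within the scatter with compound 3. The open change gives compound 4 `COc1cc(-c2ccnc3cc(-c4ccc(-c5cnn(C)c5)cc4)nn23)cc(OC)c1OC`, with 1-methyl-1H-pyrazol-4-yl in place of dimethylamino on an aromatic carbon, para to a large group: 1-methyl-1H-pyrazol-4-yl in place of dimethylamino on an aromatic carbon. Among the measured compounds shown here, two measured steps bear on it. The first is modest, a 2.5-fold lower number from compound 1 to compound 2 (0.40 log units; beyond the scatter), and the second is smaller, a 1.4-fold higher number from compound 2 to compound 3 (0.15 log units; within the scatter). No step beyond the scatter is therefore expected in this assay, and the expected change is a 1.2-fold lower number from compound 2 to compound 4 (0.07 log units; within the scatter). For compound 4 the estimate is 600 nM, with an expected range of 200 nM to 1800 nM.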

Compound 4, half-maximal inhibitory concentration: 1240 nM
Estimate against measurement, compound 4: 2.1-fold (0.32 log units) below; the measured number falls inside the stated range.
By their numbers in this assay, from the lowest: compounds 2, 3, 4 and 1 (each within the scatter of the next, the first and the last beyond it).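

In this assay the step of a 1.8-fold higher number from compound 2 to compound 4 (0.25 log units; within the scatter) and the step of a 1.4-fold lower number from compound 1 to compound 4 (0.15 log units; within the scatter) show that a five-membered aromatic ring at this place, para to a large group, is taken up with no change beyond the scatter. Compound 4 therefore lies within the scatter of both compound 1 and compound 2, although those two differ beyond it. No data at hand explain these steps.

As far as these compounds go, how morpholine, a carboxylic acid or a longer chain would read at this place remains open, as does any effect of changing the trimethoxyphenyl group.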